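Trimming a Ring Down to a Methyl

The source may report more compounds than this note shows. Statements on the series, on what has been measured and on what is new or still open speak of the compounds shown alone.

Compound 1 `O=C(NCCCCCCSSCCCCCCNC(=O)c1cc(-c2ccncc2)n[nH]1)c1cc(-c2ccncc2)n[nH]1`: in a functional assay on HCT-116 cells (Homo sapiens) for inhibition, read by MTT assay, with a stated time of 96 h (on this read-out higher numbers stand for weaker inhibition of growth and lower numbers for stronger inhibition of growth), compound 1 gives 8930 nM.
Compound 2 `O=C(NCCCCCCS)c1cc(-c2cnccn2)n[nH]1`: in this assay compound 2 gives only a limit of the assay, > 50000 nM.
Compound 3 `O=C(CCCCCCS)Nc1ccccc1`: in this assay compound 3 likewise gives only a limit, > 50000 nM.

Of the compounds shown here, three have been measured. Compound 1 joins two identical arms through a disulfide, and it is the only one of the three with a number. Compound 2 carries a free thiol on its chain, as does compound 3, an anilide with a thiol chain. Both of them sit at the limit of > 50000 nM in this assay, at which 2 of the 3 values shown sit, so where compound 2 stands can only be given as a limit, not as a number.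

Compound 4 `Cc1cc(C(=O)NCCCCCCS)[nH]n1` has not been measured. It differs from compound 2 in one place: methyl in place of pyrazin-2-yl on an aromatic carbon. The amide and the thiol chain are kept. Among the measured compounds shown here, no step between two measured compounds is available to show how a change of this kind moves the read-out, and compound 2 itself gives no number to step from. The expectation is that compound 4 also remains at the limit, because compound 2 sits at the limit of > 50000 nM in this assay, at which 2 of the 3 values shown sit, and the shown data hold nothing that would pull the smaller compound away from it. Compound 4 is therefore expected to give about 70000 nM, within a range from 20000 nM to 250000 nM, which means an expected step that the limit leaves unreadable from compound 2 to compound 4.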

Compound 4, concentration for 50% growth inhibition: > 50000 nM
Compound 4: a limit, no number; the forecaster's own chance of this, stated with the estimate: 80%; the middle value is on the limit's open side.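

In this assay compound 4 gives only a limit of the assay, > 50000 nM. Compound 2 also stands at a limit, so no step can be read from compound 2 to compound 4. The compounds shown leave open whether putting methyl in place of pyrazin-2-yl on the shared core changes inhibition of growth at all.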